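Swapping a Propyl Chain for Chlorophenyl in a Cytotoxicity Series

The compounds below may be only part of what the source reports. "The series", "measured", "known", "first", "only" and "open" are said of these compounds alone.

Measured so far:
compound 1, `CCCc1n[nH]c2c(=O)n(NC(=O)c3ccccc3)c(-c3cccc([N+](=O)[O-])c3)nc12`, 22.9%
compound 2, `CCCc1n[nH]c2c(=O)n(NC(=O)c3ccccc3)c(-c3cccc(OC)c3)nc12`, 16.7%

Both compounds share one core and differ only in the group on a ring of the side phenyl. In a functional assay on SK-MEL-2 cells (Homo sapiens) for cytotoxicity, read by sulforhodamine B assay, with a stated time of 2 days, tested at 100 uM (on this read-out lower numbers stand for less inhibition and higher numbers for more inhibition at the one concentration tested (going by the name of the read-out)), compound 1 gives 22.9%, which is the highest of the two numbers, but the step of a number 6.2 percentage points lower from compound 1 to compound 2 (within the scatter) is within the scatter, so the two cannot be told apart in this assay.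

Compound 3, `O=C(Nn1c(-c2cccc([N+](=O)[O-])c2)nc2c(-c3cccc(Cl)c3)n[nH]c2c1=O)c1ccccc1`, is not yet measured. It differs from compound 1 in another place: 3-chlorophenyl in place of propyl on an aromatic carbon, on an aromatic carbon of the five-membered ring of the shared core. Among the measured compounds shown here, no measured step touches this position, and the only step known, from nitro to methoxy, concerns a different part of the molecule and was itself within the scatter. There is therefore no measured basis for predicting a shift in either direction, and the expected step of a number 5.1 percentage points higher from compound 1 to compound 3 (within the scatter) is set close to nothing, with a wide margin. The estimate for compound 3 is 28%, in a range from 5% to 55%.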

Compound 3, a percentage reported as inhibition, at one concentration (the size of the read-out at that concentration, not a potency): 78.2%
Compound 3: the middle estimate sits 50.2 percentage points below what was measured; the measured number lies above the stated range.
By their numbers in this assay, from the lowest: compounds 2 and 1 (each within the scatter of the next); then compound 3.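

In this assay the change from propyl to 3-chlorophenyl brings a number 55.3 percentage points higher from compound 1 to compound 3 (beyond the scatter), so the read-out responds strongly to what sits on this aromatic carbon of the five-membered ring. The only earlier step, a number 6.2 percentage points lower from compound 1 to compound 2 (within the scatter), concerned the group on the side phenyl and could not separate its two compounds, which makes this the first change shown to move the number beyond the scatter. The swap adds a six-membered aromatic ring and a chlorine together, with no hydrogen-bond donors or acceptors entering or leaving, and no supporting measurement bears on what lies behind the rise.

The compounds shown cannot tell whether the ring or the chlorine carries the change, and a plain phenyl or a longer chain such as hexyl at this position would help to separate the two. Going by these compounds, it also remains open whether 3-chlorophenyl gives a similar rise when the nitro group on the side phenyl is replaced by methoxy, and since each number comes from a single concentration, none of them gives a potency.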